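Taking the remaining chloro off compound 3

The source may report more compounds than this note shows. Statements on the series, on what has been measured and on what is new or still open speak of the compounds shown alone.

In a functional assay on SJ-G2 cells (Homo sapiens) for inhibition, read by MTT assay, with a stated time of 72 h (a lower number here means a stronger inhibitor of growth, a higher number a weaker inhibitor of growth), compound 3 `O=C(NCc1ccc(Cl)cc1)c1cc(Br)c(Br)[nH]1` gives 28000 nM and compound 2 `O=C(NCc1ccc(Cl)c(Cl)c1)c1cc(Br)c(Br)[nH]1` gives 18000 nM, two values within the scatter of each other. Compound 1 `O=C(NCc1ccc(-c2ccccc2)cc1)c1cc(Br)c(Br)[nH]1` reaches only a limit, > 50000 nM. Compound 4 `O=C(NCc1ccccc1)c1cc(Br)c(Br)[nH]1` differs from compound 3 by a single change, hydrogen in place of chloro on an aromatic carbon, para to a large group. The closest guide is the same kind of swap made elsewhere on the ring, a 1.6-fold higher number from compound 2 to compound 3 (0.19 log units; within the scatter). Chloro in place of phenyl, a different change, gave an at least 1.7-fold lower number from compound 1 to compound 3 (0.25 log units; that floor lies within the scatter). The expected step is therefore small, a 1.3-fold higher number from compound 3 to compound 4 (0.10 log units; within the scatter), with nothing anticipated beyond the scatter. The estimate for compound 4 is 35000 nM, with an expected range of 18000 nM to 50000 nM.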

Compound 4, concentration for 50% growth inhibition: 11000 nM
Compound 4: the middle estimate sits 3.2-fold (0.50 log units) above what was measured, and the stated range ends above it.
By their numbers in this assay, from the lowest: compounds 4, 2 and 3 (each within the scatter of the next, the first and the last beyond it). At a limit, above all of these: compound 1.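

In this assay, hydrogen in place of the chloro para to a large group gives a 2.5-fold lower number from compound 3 to compound 4 (0.41 log units; beyond the scatter), so the unsubstituted ring inhibits growth more strongly than compound 3, whereas the same swap at the other ring position stayed within the scatter. Hydrogen in place of phenyl at this position gives an at least 4.5-fold lower number from compound 1 to compound 4 (0.65 log units; beyond the scatter). Compound 1 stands at a limit, so that step is only a floor: the limit of > 50000 nM in this assay, at which 1 of the 4 values shown sits.

As far as these compounds go, whether fluoro, methoxy or an amine at this position would match or improve on compound 4 remains open.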